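Chloro substitution in two related three-compound sets

The compounds below may be only part of what the source reports. "The series", "measured", "known", "first", "only" and "open" are said of these compounds alone.

Measured so far: Compound 1 `O=C1Nc2ccccc2C1(c1c(-c2ccccc2)[nH]c2ccccc12)c1c(-c2ccccc2)[nH]c2ccccc12` gives 8910 nM in a functional assay on A549 cells (Homo sapiens) for cytotoxicity, read by MTT assay, with a stated time of 48 h; a lower number here means a stronger inhibitor, a higher number a weaker inhibitor. Compound 2 `COC(=O)c1ccc2[nH]cc(C3(c4c[nH]c5ccc(C(=O)OC)cc45)C(=O)Nc4ccccc43)c2c1` gives 750 nM in this assay. Compound 3 `O=C1Nc2ccc(Cl)cc2C1(c1c(-c2ccccc2)[nH]c2ccccc12)c1c(-c2ccccc2)[nH]c2ccccc12` reaches only a limit of the assay, > 100000 nM, in this assay.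

Compound 2 and compound 1 have different cores; the difference between the two cores is not broken down here. In this assay compound 2 gives the lower of the two numbers, and its gap to compound 1 is beyond the scatter.

From compound 1 to compound 3 the change is chloro in place of hydrogen on an aromatic carbon, producing an at least 11-fold higher number from compound 1 to compound 3 (1.05 log units; beyond the scatter). Compound 3 sits at the limit of > 100000 nM in this assay, at which 1 of the 3 values shown sits; the size of that step is known only as a lower bound.

Compound 4 `COC(=O)c1ccc2[nH]cc(C3(c4c[nH]c5ccc(C(=O)OC)cc45)C(=O)Nc4ccc(Cl)cc43)c2c1` is not yet measured. It differs from compound 2 by chloro in place of hydrogen on an aromatic carbon, the same change as from compound 1 to compound 3. For the measured compounds named here, the expected step is a 13-fold higher number from compound 2 to compound 4 (1.12 log units; beyond the scatter), resting on an at least 11-fold higher number from compound 1 to compound 3 (1.05 log units; beyond the scatter) as the only measured instance of this change. Compound 4 is estimated at 10000 nM in this assay, expected between 2500 nM and 60000 nM.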

Compound 4, half-maximal inhibitory concentration: 71500 nM
Compound 4: the middle estimate sits 7.2-fold (0.85 log units) below what was measured; measured number above the stated range.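

In this assay, chloro in place of hydrogen on an aromatic carbon gives a 95-fold higher number from compound 2 to compound 4 (1.98 log units; beyond the scatter), so the direction of the step seen on the core of compound 1 also holds on the core of compound 2. Compound 3 gives > 100000 nM, which is a limit of the assay and not a number. Two cores show that the direction carries over, but not that the size does: the same change on two cores in this assay, an at least 11-fold higher number (1.05 log units; beyond the scatter) from compound 1 to compound 3 and a 95-fold higher number (1.98 log units; beyond the scatter) from compound 2 to compound 4; the limit leaves it open whether they differ.

The compounds shown leave open how another group, such as fluoro, methoxy or an amine, would act on the same aromatic carbon of either core. They also leave open how chloro would act on any other aromatic carbon of these cores.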